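Halogen swap on the sulfonyl ring in a bis-arylidene series

A few compounds are considered here, and "the series" means these few. Any claim that something is new, unique, unknown or untested is made for them only; others in the source may bear on it.

Measured compounds:
compound 1, `O=C1/C(=C/c2cccc(F)c2)CN(S(=O)(=O)c2ccc(F)cc2)C/C1=C\c1cccc(F)c1`: 13500 nM
compound 2, `O=C1/C(=C/c2cccc(F)c2)CN(S(=O)(=O)c2ccc(Cl)cc2)C/C1=C\c1cccc(F)c1`: 7800 nM
compound 3, `O=C1/C(=C/c2ccc(F)cc2)CN(S(=O)(=O)c2ccc(F)cc2)C/C1=C\c1ccc(F)cc1`: 14700 nM

In a functional assay on SMMC-7721 cells (Homo sapiens) for cytotoxicity, read by MTT assay, with a stated time of 24 h (a lower number here means a stronger inhibitor, a higher number a weaker inhibitor), compound 1 gives 13500 nM, compound 2 gives 7800 nM and compound 3 gives 14700 nM. All three numbers lie within the scatter of one another, so no order among them is drawn. Compound 3 and compound 1 have the same atoms joined differently; the difference between the two cores is not broken down here.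

Going by the values given here, the one counted change in the set is chloro in place of fluoro on an aromatic carbon. Its measured effect is a 1.7-fold lower number from compound 1 to compound 2 (0.24 log units; within the scatter).

Compound 4, `O=C1/C(=C/c2ccc(F)cc2)CN(S(=O)(=O)c2ccc(Cl)cc2)C/C1=C\c1ccc(F)cc1`, has not been measured in this assay. Among the compounds with values here, it differs from compound 3 by chloro in place of fluoro on an aromatic carbon, which is the same change, at the same place, as the one between compound 1 and compound 2. Within the data shown here, with only one earlier instance, and that within the scatter, the expectation for compound 4 rests on that single step. From compound 3 to compound 4 the expected step is a 1.7-fold lower number from compound 3 to compound 4 (0.23 log units; within the scatter), because the earlier instance gave a 1.7-fold lower number from compound 1 to compound 2 (0.24 log units; within the scatter). Compound 4 is therefore expected near 8600 nM, with 4300 nM to 17500 nM as the likely range.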

Compound 4, half-maximal inhibitory concentration: 7000 nM
Beside the measured number, compound 4's estimate is 1.2-fold (0.09 log units) above it; the range from low to high includes it.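

In this assay, replacing 4-fluorophenyl with 4-chlorophenyl on the core of compound 3 gives a 2.1-fold lower number from compound 3 to compound 4 (0.32 log units; beyond the scatter), and this step does not differ from the one seen on the core of compound 1: the same change on two cores in this assay, a 1.7-fold lower number (0.24 log units; within the scatter) from compound 1 to compound 2 and a 2.1-fold lower number (0.32 log units; beyond the scatter) from compound 3 to compound 4, 1.2-fold (0.08 log units) apart, within the scatter of two such steps. The change therefore carries over between these two cores, which have the same atoms joined differently, and the step measured on one core served as a fair guide to the step on the other. This does not establish a rule for the series: it rests on two pairs of compounds, the step is modest on the core of compound 3, and the step on the core of compound 1 stays within the scatter.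

Still open, as far as these compounds go, is whether the same carry-over holds for other groups in that place on the sulfonyl ring, such as bromo, methoxy, nitrile or a carboxylic acid. Also open, from the compounds shown here alone, is whether it holds on cores with other substituents on the arylidene rings, such as a methoxy group or an amine.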